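Flat series: 4-chlorophenyl in place of isopropylamino

A few compounds are considered here, and "the series" means these few. Any claim that something is new, unique, unknown or untested is made for them only; others in the source may bear on it.

In a functional assay on CCRF-CEM cells (Homo sapiens) (on this read-out lower numbers stand for stronger inhibition and higher numbers for weaker inhibition), compound 1 `CCOc1ncnc2c1ncn2C[C@@H]1C[C@H](CO)c2ccccc21` gives 24 ug/mL. Compound 2 `OC[C@H]1C[C@@H](Cn2cnc3c(Cl)ncnc32)c2ccccc21` gives 24 ug/mL. Compound 3 `CC(C)Nc1ncnc2c1ncn2C[C@@H]1C[C@H](CO)c2ccccc21` gives 24 ug/mL, level with the other two at the digits available.

The next compound is compound 4 `OC[C@H]1C[C@@H](Cn2cnc3c(-c4ccc(Cl)cc4)ncnc32)c2ccccc21`, with 4-chlorophenyl in place of isopropylamino on an aromatic carbon.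

Within the data shown here, three measured steps bear on this change, all at the same place. Chloro in place of ethoxy gives no change at the digits printed from compound 1 to compound 2 (within the scatter). Isopropylamino in place of ethoxy gives no change at the digits printed from compound 1 to compound 3 (within the scatter). Isopropylamino in place of chloro gives no change at the digits printed from compound 2 to compound 3 (within the scatter). Among the measured compounds shown here, all three are within the scatter, but no measured compound carries an aromatic ring at this place, so the new group lies outside what they cover.

In this assay the expected step is a 1.2-fold lower number from compound 3 to compound 4 (0.08 log units; within the scatter), with no shift beyond the scatter expected in either direction. For compound 4 the estimated value is 20 ug/mL, with an expected range of 8 ug/mL to 40 ug/mL.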

Compound 4, half-maximal inhibitory concentration: 0.63 ug/mL
Estimate against measurement, compound 4: 32-fold (1.50 log units) above; the whole stated range lies above it.
By their numbers in this assay, from the lowest: compound 4; then compounds 1, 2 and 3 (each within the scatter of the next).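

In this assay this position is not indifferent to its substituent: 4-chlorophenyl in place of isopropylamino gives a 38-fold lower number from compound 3 to compound 4 (1.58 log units; beyond the scatter) while the same group in place of chloro gives a 38-fold lower number from compound 2 to compound 4 (1.58 log units; beyond the scatter) and in place of ethoxy gives a 38-fold lower number from compound 1 to compound 4 (1.58 log units; beyond the scatter) on the same core. The flat read across ethoxy, chloro and isopropylamino therefore holds for those three groups only, and 4-chlorophenyl, with its six-membered aromatic ring of carbon only, is the one group shown here that moves the number beyond the scatter. No measurement available here accounts for this gain.

Going by these compounds, whether the ring alone carries the gain or its chlorine contributes stays open, and plain phenyl would separate the two. The same question stands for 4-methoxyphenyl or a pyridine ring at this place.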